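This account rests on a few compounds, and the source may have more. Where it says the series, first, only, none or still open, it means among the compounds named here.

In a functional assay on MDA-MB-231 cells (Homo sapiens) for inhibition, read by MTT assay, with a stated time of 72 h (on this read-out higher numbers stand for weaker inhibition and lower numbers for stronger inhibition), three compounds built on a shared core have been measured. Compound 1 `CC(C)(C)n1cc2c(n1)C(=O)CC1(CCN(C(=O)c3cc(-c4ccccc4Cl)nc4ccccc34)CC1)O2` gives > 10000 nM, which is a limit of the assay and not a number. Compound 2 `CC(C)(C)n1cc2c(n1)C(=O)CC1(CCN(C(=O)c3cc(-c4ccc(Br)cc4)nc4ccccc34)CC1)O2` gives > 10000 nM, which is also a limit. For the measured compounds named here, compound 3 `COc1ccc(-c2cc(C(=O)N3CCC4(CC3)CC(=O)c3nn(C(C)(C)C)cc3O4)c3ccccc3n2)cc1OC` gives 7130 nM, the only actual number among the three.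

Compound 4 `Cc1cc(C(=O)N2CCC3(CC2)CC(=O)c2nn(C(C)(C)C)cc2O3)c2ccccc2n1` has not been measured. It differs from compound 3 by methyl in place of 3,4-dimethoxyphenyl on an aromatic carbon, with methyl in place of 3,4-dimethoxyphenyl on an aromatic carbon, next to the ring nitrogen.

Two measured steps change the group at this same place: an at least 1.4-fold lower number from compound 1 to compound 3 (0.14 log units; that floor lies within the scatter) and an at least 1.4-fold lower number from compound 2 to compound 3 (0.14 log units; that floor lies within the scatter). Both are only floors, so neither establishes a real effect of that group. Going by the values given here, no measured step goes to a group as small as methyl. Among the compounds with values here, the data so far are marked by the limit of > 10000 nM in this assay, at which 2 of the 3 values shown sit, and compound 3 at 7130 nM offers the only number to start from.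

The expected change is a 1.5-fold higher number from compound 3 to compound 4 (0.19 log units; within the scatter), towards weaker inhibition and not clearly beyond the scatter. For compound 4 the estimated value is 11000 nM, within an expected range of 5000 nM to 25000 nM.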

Compound 4, half-maximal inhibitory concentration: 4860 nM
Estimate against measurement, compound 4: 2.3-fold (0.35 log units) above; the measured number lies below the stated range.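

In this assay, the methyl of compound 4, a single carbon, still gives a measurable number at this position, and a 1.5-fold lower number from compound 3 to compound 4 (0.17 log units; within the scatter) shows that it does no differently here from the far larger 3,4-dimethoxyphenyl. For the compounds shown here, two steps, an at least 2.0-fold lower number from compound 2 to compound 4 (0.31 log units; beyond the scatter) and an at least 2.0-fold lower number from compound 1 to compound 4 (0.31 log units; beyond the scatter), are the first at this position to clear the scatter, so a substituted phenyl ring here can do worse than methyl, although compound 3 shows that not every one does. Both of these sizes are floors and not exact values: the limit of > 10000 nM in this assay, at which 2 of the 4 values shown sit.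

As far as these compounds go, whether an amine, a hydroxyl or a longer chain such as propyl at this position would move the number beyond the scatter from compound 4 stays open. So does whether an unsubstituted phenyl ring would behave like compound 3 or like compound 1 and compound 2.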